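This account rests on a few compounds, and the source may have more. Where it says the series, first, only, none or still open, it means among the compounds named here.

Working notes on the octanamide series. The shared core of compound 1 `CCCCCCCCNC(=O)[C@@H](NC(=O)c1ccco1)[C@@H](C)O` carries a furan-2-yl amide on the amino side and an octyl chain on the other amide nitrogen. In a functional assay on MCF7 cells (Homo sapiens) for cytotoxicity, read by MTT assay, with a stated time of 48 h (a higher number here means a weaker inhibitor, a lower number a stronger inhibitor), compound 1 gives 91800 nM. Compound 2 `CCCCCCCCNC(=O)[C@@H](NC(=O)c1cc2ccccc2o1)[C@@H](C)O` keeps everything but the ring on the carbonyl carbon, and in this assay compound 2 gives 47200 nM. The step of a 1.9-fold lower number from compound 1 to compound 2 (0.29 log units; within the scatter) is within the scatter, so compound 1 and compound 2 are not separated by these two numbers; compound 1 simply stands at one end of the pair.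

Compound 3 `CCCCCCCCCCCCCCCCCCNC(=O)[C@@H](NC(=O)c1ccco1)[C@@H](C)O` is the chain extension of compound 1: decyl in place of hydrogen on a saturated chain carbon, eight bonds along the chain from an amide-type nitrogen. Going by the values given here, neither measured step touches the chain; the single measured step, from compound 1 to compound 2, changes only the ring on the carbonyl carbon, so nothing measured here bears on lengthening the chain. Among the compounds with values here, with no relevant precedent, the expectation for compound 3 is a step of no clear direction beyond the scatter, written as a 1.5-fold lower number from compound 1 to compound 3 (0.18 log units; within the scatter). The estimate for compound 3 in this assay is therefore 60000 nM, with a range from 12000 nM to 250000 nM.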

Compound 3, half-maximal inhibitory concentration: 21400 nM
Beside the measured number, compound 3's estimate is 2.8-fold (0.45 log units) above it; measured number inside the range.
By their numbers in this assay, from the lowest: compound 3; then compounds 2 and 1 (each within the scatter of the next).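

In this assay, going by these compounds alone, the chain gives the first step in these notes that lies beyond the scatter (a 4.3-fold lower number from compound 1 to compound 3 (0.63 log units; beyond the scatter)), for decyl in place of hydrogen on a saturated chain carbon, eight bonds along the chain from an amide-type nitrogen. The earlier step (a 1.9-fold lower number from compound 1 to compound 2 (0.29 log units; within the scatter)) changed only the ring on the carbonyl carbon and stayed within the scatter, so the chain is the one place in this set where a change is seen to separate two compounds, although the step is modest and rests on a single pair. Nothing available explains this step.

The compounds shown leave open how the number follows chain length between compound 1 and compound 3, which a dodecyl chain would begin to test, and whether it keeps falling with a chain longer than that of compound 3. Going by these compounds, it is also open whether the same extension holds on the 1-benzofuran-2-yl amide of compound 2, and what an amine or a carboxylic acid carried on the chain would do.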